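A Primary Sulfonamide Cut from an Aryl-Substituted One

This account rests on a few compounds, and the source may have more. Where it says the series, first, only, none or still open, it means among the compounds named here.

Measured compounds:
compound 1, `O=C1CS/C(=N/Nc2nncc3ccccc23)N1c1ccccc1`, 30 nM
compound 2, `Cc1cc(NS(=O)(=O)c2ccc(Nc3nncc4ccccc34)cc2)no1`, 28 nM
compound 3, `C(=C/c1ccccc1)\C(=N\Nc1nncc2ccccc12)c1ccccc1`, 5.7 nM

Of the compounds shown here, three share the same core and have been tested in a functional assay on NCI-H460 cells (Homo sapiens) for antiproliferative activity, read by sulforhodamine B assay, with a stated time of 72 h; on this read-out lower numbers stand for stronger inhibition and higher numbers for weaker inhibition. Compound 2 has the second highest number of the three. Its nearest neighbour is compound 1, whose number is higher by an amount that lies within the scatter of repeated measurements, so the two cannot be told apart. Compound 3 stands furthest away, with a number lower than that of compound 2 by an amount beyond the scatter.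

Compound 4, `NS(=O)(=O)c1ccc(Nc2nncc3ccccc23)cc1`, has not yet been measured. It differs from compound 2 in one place:

hydrogen in place of 5-methyl-1,2-oxazol-3-yl on a sulfonamide nitrogen

Among the measured compounds shown here, no step between measured compounds shows the effect of removing a group from the sulfonamide nitrogen, so there is nothing to lean on directly. The other members keep strong inhibition with quite different terminal groups, which suggests that the core carries most of the activity. A modest shift toward a higher number is expected, one that may well stay within the scatter: a 2.1-fold higher number from compound 2 to compound 4 (0.33 log units; beyond the scatter). Compound 4 is therefore estimated at 60 nM, with a range from 15 nM to 250 nM.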

Compound 4, half-maximal inhibitory concentration: 17 nM
For compound 4 the middle estimate is 3.5-fold (0.55 log units) above the measured one, within the range that was stated.
By their numbers in this assay, from the lowest: compound 3; then compounds 4, 2 and 1 (each within the scatter of the next).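

In this assay, hydrogen in place of 5-methyl-1,2-oxazol-3-yl on the sulfonamide nitrogen gives a 1.6-fold lower number from compound 2 to compound 4 (0.22 log units; within the scatter) and so leaves the two compounds indistinguishable. Among the compounds shown here, this is the first direct reading at this position, and it shows that the 5-methyl-1,2-oxazol-3-yl, with its 6 heavy atoms and its five-membered aromatic ring, is not required for activity on this read-out. Nothing measured alongside this step accounts for the result.

As far as these compounds go, one step spans only these two substituents, so it remains open whether a methyl group, an acetyl group or a phenyl ring on the same nitrogen would also leave the number within the scatter. From the compounds shown here alone, it is also open whether the sulfonamide itself matters, which a carboxylic acid or a primary carboxamide in its place would test.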